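Swapping iodo for nitro on the aryl ring of compound 3

The source may hold more compounds than are shown below. What is called first, only, known or untested is meant among the compounds shown, and "the series" means these compounds.

Measured so far in a functional assay on CHO cells for agonist activity at adenosine receptor A1 (Homo sapiens), read by fluorescence and ERK phosphorylation, with stated times of 30 min and 1.5 h, tested at 3 uM; a lower number here means a weaker effect, a higher number a stronger effect of the compound at the concentration tested:
compound 1 `Nc1scc(-c2ccccc2)c1C(=O)c1ccccc1` gives 49%
compound 2 `Nc1scc(-c2ccc(Br)cc2)c1C(=O)c1ccccc1` gives 46%
compound 3 `Nc1scc(-c2ccc(I)cc2)c1C(=O)c1ccccc1` gives 51%

Compound 3 carries the highest of the three numbers, but this says little: the step of a number 2 percentage points higher from compound 1 to compound 3 (within the scatter) and the step of a number 5 percentage points higher from compound 2 to compound 3 (within the scatter) are both within the scatter, so the three compounds cannot be ranked. The step of a number 3 percentage points lower from compound 1 to compound 2 (within the scatter) is within the scatter as well. All three differ only in what sits on one aromatic carbon of the six-membered aromatic ring of carbon only, and hydrogen, bromo and iodo there have given much the same read-out.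

Compound 4 `Nc1scc(-c2ccc([N+](=O)[O-])cc2)c1C(=O)c1ccccc1` continues this series: nitro in place of iodo on an aromatic carbon. Every measured step bears on it, in that each altered the same position, and none moved the number beyond the scatter. Within the data shown here, no measured compound carries a nitro group, so the precedent is indirect. The expectation is a step of a number 3 percentage points lower from compound 3 to compound 4 (within the scatter) that stays within the scatter, with a wide range to allow for the unfamiliar group. Compound 4 is estimated at 48% in this assay, between 30% and 65%.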

Compound 4, a percentage reported as activity, at one concentration (the size of the read-out at that concentration, not a potency): 50%
Compound 4: middle estimate off by 2 percentage points, on the low side; low and high end bracket the measured number.
By their numbers in this assay, from the lowest: compounds 2, 1, 4 and 3 (each within the scatter of the next).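

In this assay, putting nitro in place of iodo gives a number 1 percentage points lower from compound 3 to compound 4 (within the scatter) and nitro in place of bromo gives a number 4 percentage points higher from compound 2 to compound 4 (within the scatter), while nitro in place of hydrogen gives a number 1 percentage points higher from compound 1 to compound 4 (within the scatter). Among these compounds, until now this aromatic carbon had carried only hydrogen and two halogens, so the earlier compounds could not show whether a group of a different kind would matter; nitro brings nitrogen and oxygen atoms and hydrogen-bond acceptors in place of a single iodine, yet all four compounds remain within the scatter of one another. Nothing available here explains why so different a group leaves the read-out within the scatter.

The series therefore has not yet shown a group on this carbon that moves the number beyond the scatter, and whether an amine, a carboxylic acid or a longer chain such as butyl would do so remains open. These read-outs also come from a single concentration, so they leave open whether the four compounds would give a stronger or weaker effect at any other concentration.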